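The compounds below may be only part of what the source reports. "The series", "measured", "known", "first", "only" and "open" are said of these compounds alone.

Compound 1 `COc1cc(OC)c(OC)cc1/C=C/COC(=O)/C=C/c1ccccc1C(F)(F)F` offers no exact number. In a functional assay on the whole organism (strain Kunming) with Mus musculus as the target, with a stated time of 0.5 h (a higher number here means that more compound is needed for the effect, a lower number that less compound is needed), compound 1 gives > 300 mg/kg, which is a limit of the assay. Compound 2 `COc1cc(OC)c(OC)cc1/C=C/COC(=O)/C=C/c1cc(OC)c(OC)c(OC)c1` gives > 200 mg/kg, again a limit. Compound 3 `COc1cccc(/C=C/C(=O)OC/C=C/c2cc(OC)c(OC)cc2OC)c1` differs from compound 1 in one place: 3-methoxyphenyl in place of 2-(trifluoromethyl)phenyl on a double-bonded chain carbon bound to a double-bonded chain carbon, with 3-methoxyphenyl in place of 2-(trifluoromethyl)phenyl on a double-bonded chain carbon bound to a double-bonded chain carbon. For the measured compounds named here, no measured step between related compounds is available to size this change. With compound 2 also held at the limit of > 200 mg/kg, only a modest gain is expected. The expected step in this assay is an at least 1.2-fold lower number from compound 1 to compound 3 (0.07 log units; that floor lies within the scatter), towards less compound needed. Compound 3 is estimated at 250 mg/kg, within an expected range of 100 mg/kg to 500 mg/kg.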

Compound 3, dose for half-maximal effect: 249 mg/kg
Beside the measured number, compound 3's estimate is 1.0-fold (0.00 log units) above it; low and high end bracket the measured number.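

For the compounds shown here, with 3-methoxyphenyl in place of 2-(trifluoromethyl)phenyl on a double-bonded chain carbon bound to a double-bonded chain carbon, compound 3 gives the only exact number among the three compounds in this assay, so a change at this position can bring the read-out within the measurable range. The step is an at least 1.2-fold lower number from compound 1 to compound 3 (0.08 log units; that floor lies within the scatter). Its true size cannot be fixed because compound 1 stands only at a limit: the limit of > 300 mg/kg in this assay, at which 1 of the 3 values shown sits.

The compounds shown leave open whether an amine or a carboxylic acid in place of the methoxy group would lower the number beyond the scatter.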